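The source may hold more compounds than are shown below. What is called first, only, known or untested is meant among the compounds shown, and "the series" means these compounds.

Measured compounds:
Compound 1, `COc1ccc(-c2c(C)nn3c(NC4CCC4)nc(C)nc23)c(C)c1`, gives 24.6 nM in an assay on cell membranes for displacement of a labelled ligand from corticotropin-releasing factor receptor 1 (Rattus norvegicus); on this read-out lower numbers stand for stronger inhibition and higher numbers for weaker inhibition.
Compound 2, `CCCC(C)Nc1nc(C)nc2c(-c3c(C)cc(OC)cc3OC)c(C)nn12`, gives 2.14 nM in this assay.
Compound 3, `CCCN(CCC)c1nc(C)nc2c(-c3c(C)cc(OC)cc3OC)c(C)nn12`, gives 3.72 nM in this assay.

Compound 3 stands second highest of the three numbers. Its nearest neighbour is compound 2, separated by a 1.7-fold higher number from compound 2 to compound 3 (0.24 log units; within the scatter), a change from (1-methylbutyl)amino to dipropylamino that left the number essentially where it was. Compound 1 lies furthest away, its number higher by an amount beyond the scatter, but compound 1 differs from compound 3 in two places at once, both in the amino group and in the attached aryl ring, so its two values alone cannot say which of the two changes is responsible.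

Compound 4, `COc1cc(C)c(-c2c(C)nn3c(NC4CCC4)nc(C)nc23)c(OC)c1`, is not yet measured. It differs from compound 3 by cyclobutylamino in place of dipropylamino on an aromatic carbon. Within the data shown here, the only measured step at this position, from compound 2 to compound 3, was within the scatter, and no measured pair isolates the cyclobutylamino group on the shared core of compound 3. The number for compound 4 is therefore expected to stay near that of compound 3, with some chance of a modest rise toward compound 1, giving an expected step of a 2.4-fold higher number from compound 3 to compound 4 (0.38 log units; beyond the scatter).

The estimate for compound 4 in this assay is 9 nM, expected to fall between 3 nM and 30 nM.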

Compound 4, half-maximal inhibitory concentration: 17.4 nM
Beside the measured number, compound 4's estimate is 1.9-fold (0.29 log units) below it; measured number inside the range.
By their numbers in this assay, from the lowest: compounds 2 and 3 (each within the scatter of the next); then compounds 4 and 1 (each within the scatter of the next).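

In this assay the amino group on the shared core turns out to matter, since cyclobutylamino gives a 4.7-fold higher number from compound 3 to compound 4 (0.67 log units; beyond the scatter) and an 8.1-fold higher number from compound 2 to compound 4 (0.91 log units; beyond the scatter) while the earlier exchange of two open-chain amino groups gave only a 1.7-fold higher number from compound 2 to compound 3 (0.24 log units; within the scatter) and stayed within the scatter. Methoxy in place of hydrogen on an aromatic carbon gives a 1.4-fold lower number from compound 1 to compound 4 (0.15 log units; within the scatter) with cyclobutylamino in place, so on this pair the added methoxy has no readable effect. No supporting measurement is available to explain either result.

The compounds shown leave open whether the higher number follows the ring itself or the smaller count of atoms in cyclobutylamino, a question that cyclopentylamino, cyclohexylamino or open-chain butylamino on the same core could address. They also leave open whether the methoxy stays without readable effect when dipropylamino or (1-methylbutyl)amino occupies the position between the two ring nitrogen atoms.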